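Thiophene amide at the carbonyl of a piperazine-linked dioxolane

The source may report more compounds than this note shows. Statements on the series, on what has been measured and on what is new or still open speak of the compounds shown alone.

Compound 1 `O=C(CCCCc1ccccc1)Nc1ccc(N2CCN(c3ccc(OC[C@@H]4CO[C@@](Cn5cncn5)(c5ccc(Cl)cc5Cl)O4)cc3)CC2)cc1` carries a 4-phenylbutyl group on its amide carbonyl, and in a functional assay on A549 cells (Homo sapiens) for inhibition, read by MTT assay, with a stated time of 48 h (a lower number here means a stronger inhibitor, a higher number a weaker inhibitor), compound 1 gives 2610 nM. Compound 2 `O=C(Nc1ccc(N2CCN(c3ccc(OC[C@@H]4CO[C@@](Cn5cncn5)(c5ccc(Cl)cc5Cl)O4)cc3)CC2)cc1)C(/C=C/Cl)C/C=C/C(F)(F)F` replaces that chain with a 1-(2-chloroethenyl)-5,5,5-trifluoropent-3-en-1-yl group; in this assay compound 2 gives 3830 nM. Among the two numbers so far, compound 2 sits closest to compound 1, the step being a 1.5-fold higher number from compound 1 to compound 2 (0.17 log units; within the scatter).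

Compound 3 `O=C(Nc1ccc(N2CCN(c3ccc(OC[C@@H]4CO[C@@](Cn5cncn5)(c5ccc(Cl)cc5Cl)O4)cc3)CC2)cc1)c1cccs1` is the next variation at the same position: thiophen-2-yl in place of 1-(2-chloroethenyl)-5,5,5-trifluoropent-3-en-1-yl on a carbonyl carbon. Among the compounds with values here, the only measured step that bears on this change is the one at the same carbonyl, a 1.5-fold higher number from compound 1 to compound 2 (0.17 log units; within the scatter), which shows that exchanging the group on that carbon left the number essentially where it was. Compound 3 is therefore expected to show no step beyond the scatter, a 1.5-fold lower number from compound 2 to compound 3 (0.17 log units; within the scatter), in this assay. Compound 3 is estimated at 2600 nM, within a range from 1000 nM to 7000 nM.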

Compound 3, half-maximal inhibitory concentration: 4330 nM
For compound 3 the middle estimate is 1.7-fold (0.22 log units) below the measured one; the range from low to high includes it.
By their numbers in this assay, from the lowest: compounds 1, 2 and 3 (each within the scatter of the next).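

In this assay, a compact thiophen-2-yl group of 5 heavy atoms, with one five-membered aromatic ring, replaces the open 1-(2-chloroethenyl)-5,5,5-trifluoropent-3-en-1-yl chain of 11 heavy atoms, giving a 1.1-fold higher number from compound 2 to compound 3 (0.05 log units; within the scatter). Set against the 4-phenylbutyl group, the same thiophen-2-yl group gives a 1.7-fold higher number from compound 1 to compound 3 (0.22 log units; within the scatter), so the earlier finding for two chains now extends to an aromatic ring with a hetero atom: this assay does not separate the three groups on this carbonyl carbon. No supporting evidence is available that would account for this result.

On these data alone, whether any group at this place can move the number beyond the scatter remains open. A basic amine, a carboxylic acid or a simple phenyl ring on this carbonyl carbon would test that question, and the three compounds shown cannot answer it.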